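The compounds below may be only part of what the source reports. "The series", "measured", "known", "first", "only" and "open" are said of these compounds alone.

Compound 1, `COc1cc(/C=C/C(=O)c2cccc(-n3cc(-c4ccccc4)[nH]c3=O)c2)ccc1O`, gives 2730 nM in a functional assay on HCT-15 cells (Homo sapiens) for inhibition; a higher number here means a weaker inhibitor of growth, a lower number a stronger inhibitor of growth.
Compound 2, `O=C(/C=C/c1cccc(O)c1)c1cccc(-n2cc(-c3ccc(Cl)cc3)[nH]c2=O)c1`, gives 2330 nM in this assay.
Compound 3, `COc1ccc(-c2cn(-c3cccc(C(=O)/C=C/c4ccc(O)c(OC)c4)c3)c(=O)[nH]2)cc1`, gives 3150 nM in this assay.

Of these three numbers compound 3 has the highest, yet the gaps to the others are small: compound 1 lies a little lower, compound 2 a little lower still, and both gaps fall within the scatter of repeated measurements. Among the measured compounds shown here, the only step between two compounds that differ in one place, a 1.2-fold higher number from compound 1 to compound 3 (0.06 log units; within the scatter), put a methoxy group onto the aromatic ring and changed almost nothing.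

Compound 4, `COc1cc(/C=C/C(=O)c2cccc(-n3cc(-c4ccc(Cl)cc4)[nH]c3=O)c2)ccc1O`, has not yet been measured in this assay. It differs from compound 3 by chloro in place of methoxy on an aromatic carbon. For the measured compounds named here, compound 2 already carries the same chloro group on the same ring, but it also differs from compound 3 elsewhere, so no single step between them can be read; its value and that of compound 3 simply sit within the scatter of each other. Going by the values given here, the one measured change on this ring was flat, and the chloro compound on record is no different from the others beyond the scatter. For compound 4 the expected step is therefore a 1.2-fold lower number from compound 3 to compound 4 (0.08 log units; within the scatter), meaning no change beyond the scatter. The estimate for compound 4 is 2600 nM, expected to fall between 1300 nM and 5500 nM.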

Compound 4, concentration for 50% growth inhibition: 1800 nM
Estimate against measurement, compound 4: 1.4-fold (0.16 log units) above; measured number inside the range.
By their numbers in this assay, from the lowest: compounds 4, 2, 1 and 3 (each within the scatter of the next).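

In this assay, going from 4-methoxyphenyl to 4-chlorophenyl gives a 1.8-fold lower number from compound 3 to compound 4 (0.24 log units; within the scatter), and chloro in place of hydrogen on the same aromatic carbon gives a 1.5-fold lower number from compound 1 to compound 4 (0.18 log units; within the scatter). This carbon, para to a large group, has therefore now carried hydrogen, methoxy and chloro with no change that rises above the scatter, so swapping among these three groups here does not measurably alter growth inhibition in these cells. Among the compounds shown here, with the chloro group held fixed, the aromatic ring at the other end of the chain can also be read for the first time: 4-hydroxy-3-methoxyphenyl in place of 3-hydroxyphenyl gives a 1.3-fold lower number from compound 2 to compound 4 (0.11 log units; within the scatter), which is equally flat, and nothing on hand explains why these changes matter so little.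

Going by these compounds, it remains open whether a group of a different kind on the chlorine-bearing ring, such as an amine or a carboxylic acid, would move the number beyond the scatter. On these data alone, all four compounds also share the same double-bonded chain with its carbonyl, so the effect of replacing it, for instance with a saturated chain, is unknown.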